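This account rests on a few compounds, and the source may have more. Where it says the series, first, only, none or still open, it means among the compounds named here.

In a functional assay on DWD cells (Homo sapiens) for inhibition, read by sulforhodamine B assay (on this read-out higher numbers stand for weaker inhibition of growth and lower numbers for stronger inhibition of growth), compound 1 (`Cc1ccc2[nH]c(-c3ccc(-c4ccc(-c5cccc(Cl)c5)cc4)cc3)nc2c1`) gives 2510 nM and compound 2 (`COc1ccc(-c2ccc(-c3ccc(-c4nc5cc(C)ccc5[nH]4)cc3)cc2)cc1OC`) gives 1720 nM while compound 3 (`Oc1cccc2[nH]c(-c3ccc(-c4ccc(-c5ccc(C(F)(F)F)cc5)cc4)cc3)nc12`) gives 3180 nM and so stands within the scatter of both. Compound 4 (`Cc1ccc2[nH]c(-c3ccc(-c4ccc(-c5ccc(C(F)(F)F)cc5)cc4)cc3)nc2c1`) has 5-methyl-1H-benzimidazol-2-yl in place of 4-hydroxy-1H-benzimidazol-2-yl on an aromatic carbon. Within the data shown here, no measured step covers this exact change, and the one available (a 1.5-fold lower number from compound 1 to compound 2 (0.16 log units; within the scatter)) concerns another group and bears on it only loosely. Compound 1 carries the same 5-methyl-1H-benzimidazol-2-yl group at 2510 nM and lies within the scatter of compound 3, so no step beyond the scatter is expected in this assay here. The estimated move is a 1.3-fold lower number from compound 3 to compound 4 (0.10 log units; within the scatter) and that stays within the scatter. For compound 4 the estimate is 2500 nM with an expected range from 1300 nM to 4800 nM on this measure.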

Compound 4, concentration for 50% growth inhibition: 38200 nM
Estimate against measurement, compound 4: 15-fold (1.18 log units) below; measured number above the stated range.
By their numbers in this assay, from the lowest: compounds 2, 1 and 3 (each within the scatter of the next); then compound 4.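

In this assay, 5-methyl-1H-benzimidazol-2-yl in place of 4-hydroxy-1H-benzimidazol-2-yl gives a 12-fold higher number from compound 3 to compound 4 (1.08 log units; beyond the scatter), so this position is not indifferent to the change. With the 5-methyl group kept, 4-(trifluoromethyl)phenyl at the other end gives a 15-fold higher number from compound 1 to compound 4 (1.18 log units; beyond the scatter) and a 22-fold higher number from compound 2 to compound 4 (1.35 log units; beyond the scatter). Neither group alone sets the number here: the large rise appears only where the two stand together, in compound 4.

Nothing available explains this jump. As far as these compounds go, without a plain 1H-benzimidazol-2-yl group or an amine at this place, it stays open whether losing the hydroxy or gaining the methyl counts more.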